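From Phenyl to Amino on the Amide Nitrogen

The source may report more compounds than this note shows. Statements on the series, on what has been measured and on what is new or still open speak of the compounds shown alone.

The measurements here come from a functional assay on HeLa cells (Homo sapiens) for cytotoxicity, read by MTT assay, with a stated time of 72 h; on this read-out lower numbers stand for stronger inhibition and higher numbers for weaker inhibition. Among the measured compounds shown here, compound 1 `O=C(NCCNC(=O)c1cc2ccc(OCc3ccccc3)cc2oc1=O)c1cc2ccc(OCc3ccccc3)cc2oc1=O` gives 12100 nM in this assay, and compound 2 `O=C(NCCNC(=O)c1cc2ccc(OCc3cccc(Br)c3)cc2oc1=O)c1cc2ccc(OCc3cccc(Br)c3)cc2oc1=O` gives 5520 nM; these two are the only compounds for which a number rather than a limit was obtained. Compound 3 `O=C(Nc1ccccc1)c1cc2ccc(OCc3ccccc3)cc2oc1=O` carries a single copy of the shared core with a phenylcarbamoyl group, and in this assay compound 3 reaches only a limit, > 100000 nM. That limit of > 100000 nM in this assay, at which 1 of the 3 values shown sits, is where compound 3 stands, weaker than anything that was measured as a number.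

Compound 4 `NNC(=O)c1cc2ccc(OCc3ccccc3)cc2oc1=O` differs from compound 3 in one place: amino in place of phenyl on an amide-type nitrogen. For the measured compounds named here, no pair of measured compounds that differ in one place exists here, so no measured step tells how large such a change tends to be. Compound 3 is itself only a limit, so its own value cannot serve as a firm starting number. Because compound 3 stands at the limit > 100000 nM, compound 4 is expected to remain weak, with an estimated step of an at least 1.2-fold lower number from compound 3 to compound 4 (0.09 log units; that floor lies within the scatter) in this assay. The estimate for compound 4 is therefore 80000 nM, with a range from 20000 nM to 300000 nM, and a fair chance that this assay again reports only a limit.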

Compound 4, half-maximal inhibitory concentration: > 100000 nM
Compound 4: no number, only a limit (the forecaster's own chance of this, stated with the estimate: 55%); at least 1.2-fold (0.09 log units) between middle value and limit.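

In this assay compound 4 gives > 100000 nM, which is a limit and not a number. Compound 3 also stands at a limit, so no step between compound 3 and compound 4 can be read: the limit of > 100000 nM in this assay, at which 2 of the 4 values shown sit.

The compounds shown leave open how far amino in place of phenyl on an amide-type nitrogen shifts the value.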